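A longer acyl chain on the aromatic nitrogen

The source may report more compounds than this note shows. Statements on the series, on what has been measured and on what is new or still open speak of the compounds shown alone.

Measured in an ADME assay on CCRF-CEM cells (Homo sapiens) for cytotoxicity, with a stated time of 4 days; a lower number here means that less compound is tolerated, a higher number that more compound is tolerated:
Compound 1 `CNC(=O)CCCCn1c(=O)c(C)cn([C@@H]2O[C@H](CO[Si](C)(C)C(C)(C)C)[C@@]3(OS(=O)(=O)C=C3N)[C@H]2O[Si](C)(C)C(C)(C)C)c1=O` gives 10000 nM
Compound 2 `Cc1cn([C@@H]2O[C@H](CO[Si](C)(C)C(C)(C)C)[C@@]3(OS(=O)(=O)C=C3N)[C@H]2O[Si](C)(C)C(C)(C)C)c(=O)n(C(=O)c2ccccc2)c1=O` gives 54000 nM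
Compound 3 `Cc1cn([C@@H]2O[C@H](CO[Si](C)(C)C(C)(C)C)[C@@]3(OS(=O)(=O)C=C3N)[C@H]2O[Si](C)(C)C(C)(C)C)c(=O)n(C(=O)C2CC2)c1=O` gives 11000 nM

Compound 3 stands with compound 1 in the lower pair of these numbers, and compound 2 lies clear of both. The next compound to be tested is compound 4 `COC(=O)CCCC(=O)n1c(=O)c(C)cn([C@@H]2O[C@H](CO[Si](C)(C)C(C)(C)C)[C@@]3(OS(=O)(=O)C=C3N)[C@H]2O[Si](C)(C)C(C)(C)C)c1=O`, which keeps the shared core and differs by 3-(methoxycarbonyl)propyl in place of cyclopropyl on a carbonyl carbon.

Among the measured compounds shown here, the only measured swap at this place is a 4.9-fold lower number from compound 2 to compound 3 (0.69 log units; beyond the scatter), a modest step, so a change here can matter. Compound 1 carries an open chain on the aromatic nitrogen, and the comparison with it is a 1.1-fold higher number from compound 1 to compound 3 (0.04 log units; within the scatter). The step of a 5.4-fold higher number from compound 1 to compound 2 (0.73 log units; beyond the scatter) is also modest, but it involves the benzoyl group, which compound 4 lacks. In this assay, no step beyond the scatter is therefore expected. The estimated step is a 1.3-fold higher number from compound 3 to compound 4 (0.10 log units; within the scatter). Compound 4 is estimated at 14000 nM, with an expected range of 6000 nM to 40000 nM.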

Compound 4, half-maximal cytotoxic concentration: 9900 nM
Compound 4: the middle estimate sits 1.4-fold (0.15 log units) above what was measured; low and high end bracket the measured number.
By their numbers in this assay, from the lowest: compounds 4, 1 and 3 (each within the scatter of the next); then compound 2.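

In this assay the open 3-(methoxycarbonyl)propyl chain on the carbonyl carbon, in place of cyclopropyl, gives a 1.1-fold lower number from compound 3 to compound 4 (0.05 log units; within the scatter) and so shows that a ring at this place is not needed to keep the number where it was. In place of phenyl, the same chain gives a 5.5-fold lower number from compound 2 to compound 4 (0.74 log units; beyond the scatter) and so shows that the step seen with cyclopropyl is repeated by a group with no ring, leaving benzoyl as the one group shown that stands apart. The (3-(methoxycarbonyl)propyl)carbonyl group in place of 4-(methylcarbamoyl)butyl on the aromatic nitrogen gives a 1.0-fold lower number from compound 1 to compound 4 (0.00 log units; within the scatter) and so adds a second open chain that reads the same as the first.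

As far as these compounds go, whether a carboxylic acid or an amine at the end of the chain, a longer chain or a substituted benzoyl group would stay with this cluster or join compound 2 remains open. Nothing shown here gives a reason why benzoyl stands apart.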